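From phenyl to 2-fluorophenyl: working notes

The compounds below may be only part of what the source reports. "The series", "measured", "known", "first", "only" and "open" are said of these compounds alone.

All entries below come from a functional assay on MDA-MB-231 cells (Homo sapiens) for antiproliferative activity, read by MTT assay, with a stated time of 48 h (on this read-out higher numbers stand for weaker inhibition and lower numbers for stronger inhibition), and each is a limit.
- compound 1 `C/C(=C\CC/C(C)=C/CC[C@@H]1[C@@]2(C)CCC(=O)C(C)(C)[C@H]2CC[C@@]1(C)O)CC/C=C(\C)C(=O)OCc1cn(-c2ccc(C(F)(F)F)cc2)nn1`: > 150000 nM
- compound 2 `C/C(=C\CC/C(C)=C/CC[C@@H]1[C@@]2(C)CCC(=O)C(C)(C)[C@H]2CC[C@@]1(C)O)CC/C=C(\C)C(=O)OCc1cn(-c2ccccc2C)nn1`: > 150000 nM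
- compound 3 `C/C(=C\CC/C(C)=C/CC[C@@H]1[C@@]2(C)CCC(=O)C(C)(C)[C@H]2CC[C@@]1(C)O)CC/C=C(\C)C(=O)OCc1cn(-c2ccccc2)nn1`: > 150000 nM

Compound 3 stands at > 150000 nM, which is a limit and not a number. The same holds across the series, with the limit of > 150000 nM in this assay, at which 3 of the 3 values shown sit.

Compound 4 `C/C(=C\CC/C(C)=C/CC[C@@H]1[C@@]2(C)CCC(=O)C(C)(C)[C@H]2CC[C@@]1(C)O)CC/C=C(\C)C(=O)OCc1cn(-c2ccccc2F)nn1` differs from compound 3 by one change, fluoro in place of hydrogen on an aromatic carbon, ortho to a large group (fluoro in place of hydrogen on an aromatic carbon).

The nearest measured change is a step that the two limits leave unreadable from compound 2 to compound 3, hydrogen in place of methyl on an aromatic carbon. Also relevant are a step that the two limits leave unreadable from compound 1 to compound 3 and a step that the two limits leave unreadable from compound 1 to compound 2. None of these gives a size to carry over. No direction is expected in this assay, and no shift beyond the scatter, because of the limit of > 150000 nM in this assay, at which 3 of the 3 values shown sit. The expected result is a step that the limit leaves unreadable from compound 3 to compound 4. Compound 4 is estimated at 200000 nM, within a range of 100000 nM to 400000 nM, and the assay is expected to report it only as a limit.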

Compound 4, half-maximal inhibitory concentration: > 150000 nM
Compound 4 ended at the assay's limit; the forecaster's own chance of this, stated with the estimate: 90%; the middle value lies beyond the limit too.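

Compound 4 gives > 150000 nM, which is a limit and not a number. The steps to compound 4 from compound 1, compound 2 and compound 3 cannot be read, and none yields a size: the limit of > 150000 nM in this assay, at which 4 of the 4 values shown sit.

The compounds shown leave open how their four aromatic groups rank against one another.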